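Hydroxy for methoxy: one step within a cytotoxicity series

The source may hold more compounds than are shown below. What is called first, only, known or untested is meant among the compounds shown, and "the series" means these compounds.

Compound 1 `Cc1cc(O)cc(-c2nn(CC#N)cc2-c2ccnc(-c3ccc(Oc4ccccc4)cc3)c2)c1` and compound 2 `COc1cc(C)cc(-c2nn(CC#N)cc2-c2ccnc(-c3ccc(N(C)C)cc3)c2)c1` have both been run in a functional assay on NCI-H322M cells (Homo sapiens) for cytotoxicity, read by sulforhodamine B assay, with a stated time of 48 h, tested at 0.001 uM; on this read-out higher numbers stand for a weaker effect at the one concentration tested and lower numbers for a stronger effect. In this assay compound 1 gives 94%, and compound 2 gives 99% in this assay, the two numbers lying within the usual scatter of each other, so neither stands apart. Compound 3 `Cc1cc(O)cc(-c2nn(CC#N)cc2-c2ccnc(-c3ccc(N(C)C)cc3)c2)c1` awaits measurement in this assay. It differs from compound 2 by hydrogen in place of methyl on an oxygen on an aromatic ring. Compound 1 already carries the hydroxy group and sits within the scatter of compound 2. The expected step is a number 3 percentage points lower from compound 2 to compound 3 (within the scatter), none beyond the scatter. Compound 3 is estimated at 96%, between 86% and 104%.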

Compound 3, a percentage reported as activity, at one concentration (the size of the read-out at that concentration, not a potency): 94%
Beside the measured number, compound 3's estimate is 2 percentage points above it; measured number inside the range.
By their numbers in this assay, from the lowest: compounds 1, 3 and 2 (each within the scatter of the next).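

In this assay, hydrogen in place of methyl on an oxygen on an aromatic ring gives a number 5 percentage points lower from compound 2 to compound 3 (within the scatter), so this first matched reading at the position does not separate methoxy from hydroxy. With the hydroxy group in place, dimethylamino in place of phenoxy on an aromatic carbon gives no change at the digits printed from compound 1 to compound 3 (within the scatter), so that site shows no separation either at this one concentration. No supporting data bear on these readings.

From the compounds shown here alone, whether an ethoxy group or an amine at the oxygen-bearing position would read apart from these compounds remains open. Also open, going by these compounds, is whether methoxy and hydroxy separate at higher concentrations.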